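This account rests on a few compounds, and the source may have more. Where it says the series, first, only, none or still open, it means among the compounds named here.

Among the compounds with values here, compound 1 `O=C(O)Cc1sc(C(c2ccc(F)cc2)c2ccc(F)cc2)nc1-c1ccnc(F)c1` is one of two compounds measured in an in vitro functional assay on HEK285-7 cells for antagonist activity at prostaglandin D2 receptor 2 (Homo sapiens), read by BRET and beta-arrestin recruitment (on this read-out higher numbers stand for larger maximal responses and lower numbers for smaller maximal responses), where compound 1 gives 80%. The other, compound 2 `COc1ccc(C(c2ccccn2)c2nc(-c3ccc(Cl)cc3)c(CC(=O)O)s2)cc1`, gives in this assay a value of 80%, and the two numbers lie within the scatter of each other, so neither can be said to exceed the other. Compound 3 `O=C(O)Cc1sc(C(c2ccc(F)cc2)c2ccc(F)cc2)nc1-c1ccnc(O)c1` differs from compound 1 by hydroxy in place of fluoro on an aromatic carbon. Within the data shown here, no measured pair here traces such a change, so the expected step is a small one, within the scatter, estimated as a number 4 percentage points lower from compound 1 to compound 3 (within the scatter). On that basis compound 3 is expected to reach 76%, with a range of 55% to 95%.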

Compound 3, largest response reached (reported as efficacy), in percent of the reference or control that the assay uses: 60%
The estimate for compound 3 lay 16 percentage points above the measured number, and the stated range covers the measured number.
By their numbers in this assay, from the lowest: compound 3; then compounds 1 and 2 (each within the scatter of the next).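

In this assay, replacing 2-fluoropyridin-4-yl with 2-hydroxypyridin-4-yl gives a number 20 percentage points lower from compound 1 to compound 3 (beyond the scatter) and shows that the maximal response depends on the group at this position next to the ring nitrogen. The earlier compounds shown here offered no pair that could show this. No measurement shown here explains the step. From the compounds shown here alone, whether an amine or a methoxy group at the same place would read like fluoro or like hydroxy remains open. So does whether the same exchange would give a similar step on another core.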